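The source may report more compounds than this note shows. Statements on the series, on what has been measured and on what is new or still open speak of the compounds shown alone.

Compound 1 `Cc1cc(-c2ccsc2)cn2c(CSCCc3ccccc3)cnc12`: in an ADME assay on HEL cells (Homo sapiens) for cytotoxicity, with a stated time of 3 days (on this read-out higher numbers stand for lower toxicity in this test and lower numbers for higher toxicity in this test), compound 1 gives the limit > 50 ug/mL.
Compound 2 `Cc1cc(I)cn2c(CSCCc3ccccc3)cnc12`: in this assay compound 2 gives the limit > 50 ug/mL.

Compound 2 stands only as a limit in this assay, at the point described by the limit of > 50 ug/mL in this assay, at which 2 of the 2 values shown sit. Compound 3 `Cc1cc(-c2cccc(C#N)c2)cn2c(CSCCc3ccccc3)cnc12` differs from compound 2 by 3-cyanophenyl in place of iodo on an aromatic carbon. Among the measured compounds shown here, the single measured step, a step that the two limits leave unreadable from compound 1 to compound 2, bears on an aromatic-substituent exchange at the same position, yet its size is unreadable, both ends being limits. No readable step therefore sets a size or direction for compound 3 in this assay. Compound 3 is expected to give about 50 ug/mL, within 25 ug/mL to 100 ug/mL, an expected step of a number no higher from compound 2 to compound 3 (the limit leaves the size open).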

Compound 3, half-maximal cytotoxic concentration: > 50 ug/mL
Compound 3 gave a limit, no number; the forecaster's own chance of this, stated with the estimate: 70%; the middle value sits exactly at the limit.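

Compound 1, compound 2 and compound 3 all stand only as limits in this assay, so no step among them can be read: the limit of > 50 ug/mL in this assay, at which 3 of the 3 values shown sit.

The compounds shown leave open whether thiophen-3-yl, iodo and 3-cyanophenyl differ in this read-out at all.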